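Methoxybenzyl substitution carried onto the cyclohexylamino analogue

A few compounds are considered here, and "the series" means these few. Any claim that something is new, unique, unknown or untested is made for them only; others in the source may bear on it.

Among the measured compounds shown here, compound 3 (`CN1CCN(c2ccc(NC(=N)c3cc4c(-c5ccccc5)n[nH]c4c(NC4CCCCC4)n3)cc2)CC1`) gives 4630 nM in a functional assay on PC-3 cells (Homo sapiens) for cytotoxicity, read by MTT assay, with a stated time of 72 h (a lower number here means a stronger inhibitor, a higher number a weaker inhibitor), and stands as the highest number of the three measured so far. Compound 1 (`COc1cc(Nc2nc(C(=N)Nc3ccc(N4CCN(C)CC4)cc3)cc3c(-c4ccccc4)n[nH]c23)cc(OC)c1OC`) gives 4300 nM in this assay and the step of a 1.1-fold higher number from compound 1 to compound 3 (0.03 log units; within the scatter) lies within the scatter, so compound 1 and compound 3 cannot be told apart. For the measured compounds named here, compound 2 (`COc1ccc(Cn2nc(-c3ccccc3)c3cc(C(=N)Nc4ccc(N5CCN(C)CC5)cc4)nc(Nc4cc(OC)c(OC)c(OC)c4)c32)cc1`) gives 1240 nM in this assay and is the one compound clearly set apart from the other two.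

Compound 4 (`COc1ccc(Cn2nc(-c3ccccc3)c3cc(C(=N)Nc4ccc(N5CCN(C)CC5)cc4)nc(NC4CCCCC4)c32)cc1`) has not been measured. Relative to compound 3 it shows 4-methoxybenzyl in place of hydrogen on an aromatic nitrogen on the shared core. Going by the values given here, one measured step bears directly on this change, a 3.5-fold lower number from compound 1 to compound 2 (0.54 log units; beyond the scatter) on the trimethoxyphenyl-bearing core. Among the compounds with values here, only a single instance is available, so carrying it onto the cyclohexyl-bearing core rests on that one step and on the unordered values of compound 1 and compound 3. A step of similar size and direction is expected, a 3.4-fold lower number from compound 3 to compound 4 (0.54 log units; beyond the scatter) in this assay. For compound 4 the estimate in this assay is 1350 nM with a range from 600 nM to 3200 nM.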

Compound 4, half-maximal inhibitory concentration: 3540 nM
For compound 4 the middle estimate is 2.6-fold (0.42 log units) below the measured one; measured number outside the range, above it.
By their numbers in this assay, from the lowest: compound 2; then compounds 4, 1 and 3 (each within the scatter of the next).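

On the cyclohexyl-bearing core in this assay, 4-methoxybenzyl on the aromatic nitrogen gives a 1.3-fold lower number from compound 3 to compound 4 (0.12 log units; within the scatter), so the clear step seen on the trimethoxyphenyl-bearing core does not reappear clearly here, though the two steps cannot be separated: the same change on two cores in this assay, a 3.5-fold lower number (0.54 log units; beyond the scatter) from compound 1 to compound 2 and a 1.3-fold lower number (0.12 log units; within the scatter) from compound 3 to compound 4, 2.7-fold (0.42 log units) apart, within the scatter of two such steps. With 4-methoxybenzyl in place, cyclohexyl for 3,4,5-trimethoxyphenyl gives a 2.9-fold higher number from compound 2 to compound 4 (0.46 log units; beyond the scatter), a step beyond the scatter that the same exchange did not show with hydrogen on that nitrogen, yet these two steps also cannot be separated: the same change on two cores in this assay, a 1.1-fold higher number (0.03 log units; within the scatter) from compound 1 to compound 3 and a 2.9-fold higher number (0.46 log units; beyond the scatter) from compound 2 to compound 4, 2.7-fold (0.42 log units) apart, within the scatter of two such steps. Among the compounds shown here, compound 2 remains the only compound set apart from the other three.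

On these data alone, whether the two groups truly depend on each other or the gap between the steps is only scatter remains open. Also open, as far as these compounds go, is how a plain benzyl or a methyl on that aromatic nitrogen would read on either core.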